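Pyrrole series: cyclopropylsulfonyl to methylsulfonyl

The source may report more compounds than this note shows. Statements on the series, on what has been measured and on what is new or still open speak of the compounds shown alone.

Measured so far:
compound 1 `Cc1c(C(=O)NCCCN2CCN(C)CC2)c(-c2cccc(N3CCN(c4ccc(NS(=O)(=O)c5cccc(S(=O)(=O)C6CC6)c5)cc4)CC3)c2)c(-c2ccc(Cl)cc2)n1C` gives 218 nM
compound 2 `CCCCn1c(C)c(C(=O)O)c(-c2cccc(N3CCN(c4ccc(NS(=O)(=O)c5ccc(N[C@H](CCN6CCC(O)CC6)CSc6ccccc6)c(S(=O)(=O)C(F)(F)F)c5)cc4)CC3)c2)c1-c1ccc(Cl)cc1` gives 20 nM
compound 3 `Cc1c(C(=O)O)c(-c2cccc(N3CCN(c4ccc(NS(=O)(=O)c5ccc(N[C@H](CCN6CCC(O)CC6)CSc6ccccc6)c(S(=O)(=O)C(F)(F)F)c5)cc4)CC3)c2)c(-c2ccc(Cl)cc2)n1C(C)C` gives 0.8 nM

All three numbers come from an assay for binding affinity to Apoptosis regulator Bcl-2 (Homo sapiens), read by fluorescence polarization, with a stated time of 2 h; on this read-out lower numbers stand for stronger inhibition and higher numbers for weaker inhibition. Compound 1 stands at the highest number of the three, the weakest binder in this set: compound 2 sits at a lower number, compound 3 lower still. Both gaps lie beyond the scatter. Compounds 2 and 3 differ from compound 1 in several places at once, so none of these pairs yields a single clean step, and nothing in them speaks directly to the change that separates compound 1 from compound 4.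

Compound 4 `Cc1c(C(=O)NCCCN2CCN(C)CC2)c(-c2cccc(N3CCN(c4ccc(NS(=O)(=O)c5cccc(S(C)(=O)=O)c5)cc4)CC3)c2)c(-c2ccc(Cl)cc2)n1C` is obtained from compound 1 by a single change: methyl in place of cyclopropyl on a sulfonyl sulfur. The rest of the molecule is kept. Within the data shown here, with no matched pair on hand for this exchange, the expectation rests on its small size only: the step from compound 1 to compound 4 is expected to be small, of about the size a 1.4-fold higher number from compound 1 to compound 4 (0.14 log units; within the scatter), that is, no change beyond the scatter, and if anything a slight rise in the number. For compound 4 in this assay the estimate is 300 nM, with a range from 120 nM to 800 nM.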

Compound 4, inhibition constant: 658 nM
Compound 4: middle estimate off by 2.2-fold (0.34 log units), on the low side, and the stated range covers the measured number.
By their numbers in this assay, from the lowest: compound 3; then compound 2; then compound 1; then compound 4.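

In this assay, among these compounds, the exchange of cyclopropyl for methyl on a sulfonyl sulfur gives the first single-place reading, a 3.0-fold higher number from compound 1 to compound 4 (0.48 log units; beyond the scatter) and so the group at this place is not neutral for the number, although the step is modest. The earlier compounds shown here differed from compound 1 in several places at once and could not isolate this place; with the rest of the molecule held fixed, the step belongs to this exchange alone, in which a three-membered ring of three carbons gives way to a single carbon. Nothing measured here bears on why the number rises, and the step alone cannot separate the loss of the ring from the loss of carbon count.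

Still open, from the compounds shown here alone, is whether the number at this place follows the ring or the carbon count: an ethyl group, with no ring, and a cyclobutyl ring on the same sulfonyl sulfur would help separate the two readings. Also open, going by these compounds, is whether the same exchange moves the number to a similar extent on other parts of the series, such as the background of compound 3.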